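Changing the aryl group on the ring nitrogen of compound 1

The source may report more compounds than this note shows. Statements on the series, on what has been measured and on what is new or still open speak of the compounds shown alone.

Compound 1 `Nc1scc(CN2CCN(c3cccc(Cl)c3Cl)CC2)c1C(=O)c1ccc(Cl)cc1` is the starting point. In a functional assay on CHO cells with adenosine receptor A1 (Homo sapiens) as the target, read by cAMP accumulation and immunoassay, with a stated time of 6 min, tested at 10 uM (on this read-out lower numbers stand for a stronger effect and higher numbers for a weaker effect at the one concentration tested), compound 1 gives -77%, the lowest of the three numbers shown, though compound 2 sits within the scatter of it. Compound 2 `Nc1scc(CN2CCN(c3cc(Cl)cc(Cl)c3)CC2)c1C(=O)c1ccc(Cl)cc1` gives -74%, and compound 3 `Nc1scc(CN2CCN(c3ccccc3C(F)(F)F)CC2)c1C(=O)c1ccc(Cl)cc1` gives -60%. Compound 4 `Nc1scc(CN2CCN(c3ccc(OC(F)(F)F)cc3)CC2)c1C(=O)c1ccc(Cl)cc1` differs from compound 1 in one place: 4-(trifluoromethoxy)phenyl in place of 2,3-dichlorophenyl on an amine nitrogen in a ring. The most relevant measured step is a number 17 percentage points higher from compound 1 to compound 3 (beyond the scatter), where a different group also replaced 2,3-dichlorophenyl; a number 14 percentage points higher from compound 2 to compound 3 (beyond the scatter) points the same way, whereas a number 3 percentage points higher from compound 1 to compound 2 (within the scatter). Within the data shown here, no measured step introduces 4-(trifluoromethoxy)phenyl, so the expectation rests on that analogy alone. Compound 4 is therefore expected to show a modest weakening, a number 15 percentage points higher from compound 1 to compound 4 (beyond the scatter). The estimate for compound 4 is -62%, expected to fall between -80% and -40%.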

Compound 4, a percentage reported as activity, at one concentration (the size of the read-out at that concentration, not a potency): -74%
Compound 4: the middle estimate sits 12 percentage points above what was measured, and the stated range covers the measured number.
By their numbers in this assay, from the lowest: compounds 1, 2 and 4 (each within the scatter of the next); then compound 3.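

In this assay the new group gives a number 3 percentage points higher from compound 1 to compound 4 (within the scatter) and no change at the digits printed from compound 2 to compound 4 (within the scatter) so an aryl group without chlorine can match both dichlorophenyl compounds on this ring nitrogen. Fluorine on the aryl group does not by itself bring the weaker number of compound 3, as the change is a number 14 percentage points lower from compound 3 to compound 4 (beyond the scatter) and compound 4 also carries fluorine. No measurement shown gives a reason for this difference.

Still open, on these data alone, is whether an amine or a carboxylic acid on the phenyl ring would keep the number. As far as these compounds go, a plain methyl group in place of the aryl group is equally open.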